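Methoxy addition on the lactone and lactam series

The compounds below may be only part of what the source reports. "The series", "measured", "known", "first", "only" and "open" are said of these compounds alone.

Compound 1 `COc1cc(/C=C/C2CC=CC(=O)O2)cc(OC)c1` carries the shared core as a lactone; in a functional assay on HT-29 cells (Homo sapiens) for inhibition, read by sulforhodamine B assay, with a stated time of 48 h (a higher number here means a weaker inhibitor of growth, a lower number a stronger inhibitor of growth), compound 1 gives 8.2 uM. Compound 2 `COc1cc(/C=C/C2CC=CC(=O)O2)cc(OC)c1OC` differs by methoxy in place of hydrogen on an aromatic carbon, and in this assay compound 2 gives 18.8 uM; the step is a 2.3-fold higher number from compound 1 to compound 2 (0.36 log units; beyond the scatter). Compound 3 `COc1ccc(/C=C/C2CC=CC(=O)N2)cc1` carries the lactam core; the difference between the two cores is not broken down here. In this assay compound 3 reaches only the limit of > 1090 uM, which is a limit of the assay, not a number. Compound 4 `COc1ccc(/C=C/C2CC=CC(=O)N2)c(OC)c1` is not yet measured; it differs from compound 3 by methoxy in place of hydrogen on an aromatic carbon. This is the same kind of change as from compound 1 to compound 2, but the surroundings differ: there the entering group sat ortho to two methoxy groups and para to a group of 9 heavy atoms, here ortho to a group of 9 heavy atoms and meta to a methoxy group. Because the limit of > 1090 uM in this assay, at which 1 of the 3 values shown sits, already holds for compound 3, compound 4 is expected to stay at or beyond that limit, about 1500 uM, with a step that the limit leaves unreadable from compound 3 to compound 4 expected in this assay.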

Compound 4, concentration for growth inhibition (reported as GI): > 964 uM
Compound 4: a limit, no number (the forecaster's own chance of this, stated with the estimate: 80%); the middle value lies beyond the limit too.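

In this assay compound 3 gives > 1090 uM, a limit of the assay and not a number. Compound 4 gives > 964 uM, likewise a limit, and the step between these two compounds cannot be read. The compounds shown leave open whether methoxy in place of hydrogen on an aromatic carbon changes growth inhibition at all on the core of compound 3.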